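The compounds below may be only part of what the source reports. "The series", "measured", "known", "first", "only" and "open" are said of these compounds alone.

Measured in a toxicity assay on CCRF-CEM cells (Homo sapiens) for cytotoxicity; on this read-out higher numbers stand for lower toxicity in this test and lower numbers for higher toxicity in this test:
- Compound 1 `COC(=O)c1cccc2c1nc(-c1c(F)cccc1F)n2Cc1c(F)cccc1F`: 57.7 uM
- Compound 2 `Nc1cccc2c1nc(-c1c(F)cccc1F)n2Cc1c(F)cccc1F`: 26.3 uM
- Compound 3 `CC(=O)N(C)c1cccc2c1nc(-c1c(F)cccc1F)n2Cc1c(F)cccc1F`: > 100 uM

Compound 3 stands at the limit of > 100 uM in this assay, at which 1 of the 3 values shown sits; its entry is a limit and not a number. Compound 4 `N=C(NO)c1cccc2c1nc(-c1c(F)cccc1F)n2Cc1c(F)cccc1F` differs from it on an aromatic carbon: a group of 4 heavy atoms (1 carbon, 2 nitrogen, 1 oxygen; no ring) in place of a group of 5 heavy atoms (3 carbon, 1 nitrogen, 1 oxygen; no ring), on an aromatic carbon. Among the compounds with values here, no measured step makes this exact change, but two steps end on the group that compound 4 loses. These are an at least 3.8-fold higher number from compound 2 to compound 3 (0.58 log units; beyond the scatter) and an at least 1.7-fold higher number from compound 1 to compound 3 (0.23 log units; that floor lies within the scatter), and only the first clears the scatter. Leaving that group is therefore expected to give a modest move toward a lower number in this assay. The expected step is an at least 2.0-fold lower number from compound 3 to compound 4 (0.30 log units; that floor lies within the scatter). For compound 4 the estimated value is 50 uM, with an expected range of 18 uM to 100 uM.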

Compound 4, half-maximal toxic concentration: 23.1 uM
For compound 4 the middle estimate is 2.2-fold (0.34 log units) above the measured one, within the range that was stated.
By their numbers in this assay, from the lowest: compounds 4 and 2 (each within the scatter of the next); then compound 1. At a limit, above all of these: compound 3.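

In this assay, leaving acetyl(methyl)amino on this aromatic carbon gives an at least 4.3-fold lower number from compound 3 to compound 4 (0.63 log units; beyond the scatter). Compound 3 is a limit and not a number: the limit of > 100 uM in this assay, at which 1 of the 4 values shown sits. The new group also gives a 1.1-fold lower number from compound 2 to compound 4 (0.06 log units; within the scatter) and a 2.5-fold lower number from compound 1 to compound 4 (0.40 log units; beyond the scatter), so this larger group and the amino group read alike here, while methoxycarbonyl stands apart from compound 4.

The compounds shown leave open whether a carboxylic acid or a nitrile here would read with compound 4 or with compound 1. They also leave open whether methylamino or acetylamino alone would match compound 3.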